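This account rests on a few compounds, and the source may have more. Where it says the series, first, only, none or still open, it means among the compounds named here.

Measured in a functional assay on U-87MG ATCC cells (Homo sapiens) for cytotoxicity, read by MTT assay, with a stated time of 48 h; a lower number here means a stronger inhibitor, a higher number a weaker inhibitor:

compound 1 `CC(=NNC(=S)Nc1ccc(Cl)cc1)c1ccccn1`: 1.7 nM
compound 2 `CC(=NNC(=S)Nc1ccccc1)c1ccccn1`: 1.4 nM
compound 3 `CC(=NNC(=S)Nc1ccc(F)cc1)c1ccccn1`: 10 nM

On these three numbers compound 2 gives the lowest value, but its step to compound 1, a 1.2-fold lower number from compound 1 to compound 2 (0.08 log units; within the scatter), lies within the scatter, so no order between compound 1 and compound 2 can be read. Going by the values given here, the only steps beyond the scatter are those to compound 3: a 5.9-fold higher number from compound 1 to compound 3 (0.77 log units; beyond the scatter) and a 7.1-fold higher number from compound 2 to compound 3 (0.85 log units; beyond the scatter), both modest.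

Compound 4 `C/C(=N\NC(=S)Nc1ccccc1)c1ccccn1` is the next entry. Against compound 2: the two compounds have the same atoms and bonds; at least one stereo element is drawn with a configuration in one of them and without one in the other: 1 of 1 stereo elements differ; a double bond is drawn without a configuration in compound 2 and E in compound 4. Among the compounds with values here, none of the measured steps bears on this change; each of them swaps a substituent on an aromatic carbon, whereas here no atom leaves and none enters, and only the drawn configuration of the double bond differs. The expected step of no change at the digits printed from compound 2 to compound 4 (within the scatter) is therefore none beyond the scatter. Compound 4 is expected to give about 1.4 nM in this assay, within a range of 0.6 nM to 3.5 nM.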

Compound 4, half-maximal inhibitory concentration: 1.4 nM
For compound 4 middle estimate and measured number coincide at the digits printed; measured number inside the range.
By their numbers in this assay, from the lowest: compounds 2, 4 and 1 (each within the scatter of the next); then compound 3.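

In this assay, drawing the double bond as E rather than without a configuration gives no change at the digits printed from compound 2 to compound 4 (within the scatter). Unlike the earlier steps, which swap a substituent on an aromatic carbon, this one concerns the drawn configuration, and it opens no gap beyond the scatter at this double bond. The pair cannot show whether configuration matters, since only one defined form appears and the other entry states none: the fact that one of compounds 2 and 4 is drawn with a defined configuration and the other without, at the place where they differ.

The compounds shown carry only chloro, fluoro or hydrogen on the aromatic carbon, and no entry has the double bond drawn as Z, so a comparison of E and Z remains open. Also open, going by these compounds, is how an amine in place of the chloro, or a longer chain in place of the methyl on the double bond, would read in this assay.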